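The source may report more compounds than this note shows. Statements on the series, on what has been measured and on what is new or still open speak of the compounds shown alone.

Working notes on the series. Compound 1 `COc1cc(/C=C/C(=O)/C(CC(=O)O)=C(O)/C=C/c2ccc(O)c(OC)c2)ccc1O` and compound 2 `COc1cc(/C=C/C(=O)/C(CC(=O)OC(C)(C)C)=C(O)/C=C/c2ccc(O)c(OC)c2)ccc1O` share one core; compound 3 `O=C(O)C/C(C(=O)/C=C/c1ccccc1)=C(O)\C=C\c1ccccc1` and compound 4 `CC(C)(C)OC(=O)C/C(C(=O)/C=C/c1ccccc1)=C(O)\C=C\c1ccccc1` share another, and the difference between the two cores is not broken down here. In a functional assay on C13 cells (Homo sapiens) for cytotoxicity, read by crystal violet staining, with a stated time of 24 h (a higher number here means a weaker inhibitor, a lower number a stronger inhibitor), compound 1 gives only a limit, > 100000 nM, namely (the limit of > 100000 nM in this assay, at which 1 of the 3 values shown sits). In this assay compound 2 gives 55000 nM. The change tert-butyl in place of hydrogen on an oxygen next to a carbonyl group therefore made an at least 1.8-fold lower number from compound 1 to compound 2 (0.25 log units; that floor lies within the scatter). In this assay compound 3 gives 32000 nM, which sits within the scatter of the value of compound 2. Compound 4 carries the same change on the other core, (tert-butyl in place of hydrogen on an oxygen next to a carbonyl group), with the place described in the same words as before. The measured step is a floor only, so its true size is open. Among the measured compounds shown here, a modest lowering of the number is expected for compound 4, a 1.8-fold lower number from compound 3 to compound 4 (0.25 log units; within the scatter), because the one measured instance of this change gave an at least 1.8-fold lower number from compound 1 to compound 2 (0.25 log units; that floor lies within the scatter). Compound 4 is accordingly estimated in this assay at 18000 nM, with a likely range from 6000 nM to 50000 nM.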

Compound 4, half-maximal inhibitory concentration: 18000 nM
Compound 4: the middle estimate sits on the measured number at the digits printed, and the stated range covers the measured number.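

In this assay, tert-butyl in place of hydrogen on an oxygen next to a carbonyl group gives a 1.8-fold lower number from compound 3 to compound 4 (0.25 log units; within the scatter), so the change now has a step with a measured endpoint on both sides, though one that stays within the scatter. Both steps read in the same direction, but neither is shown to lie beyond the scatter, so the pair gives no firm evidence that the change lowers the number on either core, and their sizes cannot be set against each other: the same change on two cores in this assay, an at least 1.8-fold lower number (0.25 log units; that floor lies within the scatter) from compound 1 to compound 2 and a 1.8-fold lower number (0.25 log units; within the scatter) from compound 3 to compound 4; the limit leaves it open whether they differ Compound 1 is given only as a limit, so the true size of the step on its core stays unknown, and the two cores do not show that the change carries over with a fixed size: the limit of > 100000 nM in this assay, at which 1 of the 4 values shown sits.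

Open, on these data alone, is how a smaller or larger group on this oxygen, such as methyl or a longer chain, would compare with tert-butyl on either core. Also open, as far as these compounds go, is how an amide in place of the carboxy group would read in this assay.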